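Oxazole ketone series: aryl group exchange on the core

This account rests on a few compounds, and the source may have more. Where it says the series, first, only, none or still open, it means among the compounds named here.

Among the compounds with values here, compound 2 `N#Cc1cccc(-c2cnc(C(=O)CCCCCCc3ccccc3)o2)c1` gives 15 nM in an assay (Rattus norvegicus) for inhibition of Fatty-acid amide hydrolase 1 (Homo sapiens) (a higher number here means a weaker inhibitor, a lower number a stronger inhibitor), the lower of the two numbers measured so far; compound 1 `N#Cc1ccccc1-c1cnc(C(=O)CCCCCCc2ccccc2)o1` gives 130 nM in this assay. Within the data shown here, the single measured step, an 8.7-fold lower number from compound 1 to compound 2 (0.94 log units; beyond the scatter), changed only the cyanophenyl group. Compound 3 `O=C(CCCCCCc1ccccc1)c1ncc(-c2ccc(O)cc2)o1` differs from compound 2 by 4-hydroxyphenyl in place of 3-cyanophenyl on an aromatic carbon. Among the measured compounds shown here, no measured step exchanges a nitrile for a hydroxyl, so the direction of this step is open; the one step on record shows that the aryl group alone can shift the number beyond the scatter. Compound 3 is estimated at 30 nM, range 8 nM to 120 nM, an expected step of a 2.0-fold higher number from compound 2 to compound 3 (0.30 log units; within the scatter).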

Compound 3, inhibition constant: 140 nM
Estimate against measurement, compound 3: 4.7-fold (0.67 log units) below; the whole stated range lies below it.
By their numbers in this assay, from the lowest: compound 2; then compounds 1 and 3 (each within the scatter of the next).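

In this assay a second aryl exchange on this aromatic carbon moves the number beyond the scatter, with a 9.3-fold higher number from compound 2 to compound 3 (0.97 log units; beyond the scatter). 4-Hydroxyphenyl and 2-cyanophenyl are not separated, with a 1.1-fold higher number from compound 1 to compound 3 (0.03 log units; within the scatter), so of the three aryl groups only 3-cyanophenyl stands apart. No evidence at hand accounts for this difference.

Open, as far as these compounds go, is whether the number follows the group or its place on the phenyl ring, which 3-hydroxyphenyl and 4-cyanophenyl would separate. Also open, from the compounds shown here alone, is how an amine or a carboxylic acid on that ring would compare.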